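Swapping the aryl group on the ring nitrogen

The compounds below may be only part of what the source reports. "The series", "measured", "known", "first", "only" and "open" are said of these compounds alone.

Among the compounds with values here, compound 2 `CCc1cccc(CC)c1-n1nncc1CN1C(=O)C2(C(C#N)=C(N)Oc3c(N)cc4nc5ccccc5nc4c32)c2ccccc21` is the only compound with an actual number in a functional assay on HepG2 cells (Homo sapiens) for antiproliferative activity, read by MTT assay, with a stated time of 48 h (on this read-out lower numbers stand for stronger inhibition and higher numbers for weaker inhibition), where compound 2 gives 16500 nM. Compound 1 `Cc1ccccc1-n1nncc1CN1C(=O)C2(C(C#N)=C(N)Oc3c(N)cc4nc5ccccc5nc4c32)c2ccccc21` gives > 50000 nM in this assay, which is a limit of the assay rather than a number (the limit of > 50000 nM in this assay, at which 1 of the 2 values shown sits). Within the data shown here, the one measured comparison is an at least 3.0-fold lower number from compound 1 to compound 2 (0.48 log units; beyond the scatter). Compound 3 `N#CC1=C(N)Oc2c(N)cc3nc4ccccc4nc3c2C12C(=O)N(Cc1cnnn1-c1c(Cl)cc(Cl)cc1Cl)c1ccccc12` differs from compound 2 by 2,4,6-trichlorophenyl in place of 2,6-diethylphenyl on an aromatic nitrogen. That earlier step also exchanged one aryl group at the same place, and a change of similar size is plausible, but a single comparison does not fix its direction. Compound 3 is expected to give about 15000 nM, between 5000 nM and 50000 nM. The expected step is a 1.1-fold lower number from compound 2 to compound 3 (0.04 log units; within the scatter).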

Compound 3, half-maximal inhibitory concentration: 37800 nM
The estimate for compound 3 lay 2.5-fold (0.40 log units) below the measured number; low and high end bracket the measured number.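

Replacing one aryl group with another on the ring nitrogen can move the result in either direction, and here 2,4,6-trichlorophenyl in place of 2,6-diethylphenyl gives a 2.3-fold higher number from compound 2 to compound 3 (0.36 log units; beyond the scatter). The other new comparison, an at least 1.3-fold lower number from compound 1 to compound 3 (0.12 log units; that floor lies within the scatter), cannot be read as a real difference. Compound 1 gives only a limit of the assay, not a number: the limit of > 50000 nM in this assay, at which 1 of the 3 values shown sits.

With so few aryl groups shown, no trend can be drawn across them. As far as these compounds go, whether a plain phenyl, or a phenyl carrying a methoxy group or an amine, would give a number lower than that of compound 2 remains open.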